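Chain Length and Ring Configuration in an Antiproliferative Series

A few compounds are considered here, and "the series" means these few. Any claim that something is new, unique, unknown or untested is made for them only; others in the source may bear on it.

Compound 1 `CCCCCCCn1cc(COC[C@@H]2OC[C@H](N)[C@@H]2O)nn1` pairs a sugar-like core with a saturated chain attached at an aromatic nitrogen. In a functional assay on EC9706 cells (Homo sapiens) for antiproliferative activity, read by MTT assay, with a stated time of 48 h (a higher number here means a weaker inhibitor, a lower number a stronger inhibitor), compound 1 gives only a limit of the assay, > 128000 nM, and no number. Compound 2 `CCCCCCCCn1cc(COC[C@@H]2OC[C@H](N)[C@@H]2O)nn1` adds one carbon to that chain; the change is methyl in place of hydrogen on a saturated chain carbon, seven bonds along the chain from an aromatic nitrogen. In this assay compound 2 gives 44300 nM. This step, an at least 2.8-fold lower number from compound 1 to compound 2 (0.46 log units; beyond the scatter), is read against (the limit of > 128000 nM in this assay, at which 2 of the 3 values shown sit). Compound 3 `CCCCCCCCn1cc(COC[C@@H]2OC[C@H](N)[C@H]2O)nn1` has the same atoms and bonds as compound 2 and differs only in the configuration drawn at one saturated ring carbon. In this assay compound 3 gives only a limit of the assay, > 128000 nM, and no number. The step of an at least 2.8-fold higher number from compound 2 to compound 3 (0.46 log units; beyond the scatter) rests on (the fact that compounds 2 and 3 differ only in the configuration as drawn).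

Compound 4 `CCCCCCCCCn1cc(COC[C@@H]2OC[C@H](N)[C@H]2O)nn1` lengthens the chain of compound 3 by one carbon; the change is methyl in place of hydrogen on a saturated chain carbon, eight bonds along the chain from an aromatic nitrogen. This is the same kind of change as that from compound 1 to compound 2, but the place differs: seven bonds along the chain from an aromatic nitrogen there, eight bonds here. How the core of compound 3 differs from that of compound 1 is not broken down here.

In this assay the step from compound 3 to compound 4 is expected to be about an at least 1.4-fold lower number from compound 3 to compound 4 (0.15 log units; that floor lies within the scatter), smaller than an at least 2.8-fold lower number from compound 1 to compound 2 (0.46 log units; beyond the scatter), since compound 3 sits at a limit, > 128000 nM, and its configuration already weakened the series. Compound 4 is estimated at 90000 nM, within 30000 nM to 200000 nM.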

Compound 4, half-maximal inhibitory concentration: > 128000 nM
Compound 4: only a limit was reported (the forecaster's own chance of this, stated with the estimate: 50%); at least 1.4-fold (0.15 log units) between middle value and limit.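

In this assay compound 4 gives only a limit of the assay, > 128000 nM, and no number. Compound 3 also gives only a limit, so no new step can be read from compound 3 to compound 4, and the reading rests on this: the limit of > 128000 nM in this assay, at which 3 of the 4 values shown sit. The compounds shown leave open whether the longer chain of compound 4 changes activity at all, with either ring configuration.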